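A few compounds are considered here, and "the series" means these few. Any claim that something is new, unique, unknown or untested is made for them only; others in the source may bear on it.

Measured so far in a functional assay on RCC4 cells (Homo sapiens) for antiproliferative activity, read by XTT assay, with a stated time of 48 h; on this read-out lower numbers stand for stronger inhibition and higher numbers for weaker inhibition:
- compound 1 `CC(=O)OC[C@H]1O[C@@H](n2cc(CN(c3ccc(C#N)cc3)S(C)(=O)=O)nn2)[C@H](OC(C)=O)[C@@H](OC(C)=O)[C@@H]1OC(C)=O`: 120000 nM
- compound 2 `COC(=O)CN(Cc1cn([C@@H]2O[C@H](COC(C)=O)[C@@H](OC(C)=O)[C@H](OC(C)=O)[C@H]2OC(C)=O)nn1)S(C)(=O)=O`: > 250000 nM

Within the data shown here, the entry for compound 2 is a limit, so compound 1 holds the only true number. In compound 3 `CC(=O)OC[C@H]1O[C@@H](n2cc(CN(c3ccc(C#N)cc3)S(C)(=O)=O)nn2)[C@@H](OC(C)=O)[C@@H](OC(C)=O)[C@@H]1OC(C)=O` the change is the two compounds have the same atoms and bonds and differ only in configuration as drawn: 1 of 5 stereo elements differ; a stereocentre at a saturated ring carbon is drawn R in compound 1 and S in compound 3. Among the measured compounds shown here, the one measured step, an at least 2.0-fold higher number from compound 1 to compound 2 (0.31 log units; beyond the scatter), concerns a sulfonamide nitrogen and not the ring stereocentre, so it offers no direct guide; the limit of > 250000 nM in this assay, at which 1 of the 2 values shown sits, marks the ceiling. No step beyond the scatter is expected in this assay. The expected step is a 1.1-fold higher number from compound 1 to compound 3 (0.03 log units; within the scatter). For compound 3 the estimated value is 130000 nM, with an expected range of 55000 nM to 250000 nM.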

Compound 3, half-maximal inhibitory concentration: 240000 nM
Beside the measured number, compound 3's estimate is 1.8-fold (0.27 log units) below it; the measured number falls inside the stated range.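

In this assay, drawing this saturated ring carbon S rather than R gives a 2.0-fold higher number from compound 1 to compound 3 (0.30 log units; within the scatter). Among these compounds, this is the first look at configuration, and at this stereocentre it separates the two compounds by no more than the usual scatter, with only one structural difference to weigh: the fact that compounds 1 and 3 differ only in the configuration as drawn. The room for reading any change is also narrow: the limit of > 250000 nM in this assay, at which 1 of the 3 values shown sits.

Still open, going by these compounds, is whether the other ring stereocentres behave the same way. Also open, on these data alone, is whether a carboxylic acid or an amine on the sulfonamide nitrogen would move the number well away from the ceiling.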